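A few compounds are considered here, and "the series" means these few. Any claim that something is new, unique, unknown or untested is made for them only; others in the source may bear on it.

Among the compounds with values here, compound 1, `COC1=C(C)C(=O)/C(=C(O)/C=C/c2cccc(OC)c2)C(=O)C1(C)C`, is the only member of this set with a number attached to it: in a functional assay on 1A9 cells (Homo sapiens) for cytotoxicity (a lower number here means that less compound is needed, a higher number that more compound is needed for the effect), compound 1 gives 2.9 ug/mL. Within the data shown here, two related compounds stand beside it without any result: compound 2, `COC1=C(C)C(=O)/C(=C(O)/C=C/c2c(C)cccc2C)C(=O)C1(C)C`, for which this assay shows "not determined" (no result reported), and compound 3, `COC1=C(C)C(=O)/C(=C(O)/C=C/c2cc(C)cc(C)c2)C(=O)C1(C)C`, for which it shows "not determined" (no result reported); each carries a methyl-substituted phenyl ring on the same chain, but no number was reported for either of them in this assay, so they offer no comparison and no step can be drawn from them.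

Compound 4, `COC1=C(C)C(=O)/C(=C(O)/C=C/c2nccs2)C(=O)C1(C)C`, differs from compound 1 at one place: 1,3-thiazol-2-yl in place of 3-methoxyphenyl on a double-bonded chain carbon bound to a double-bonded chain carbon. Among the measured compounds shown here, no measured pair in this set shows what such an exchange does in this assay, so the expected size of the step rests only on the structural change itself. Because compound 1 gives 2.9 ug/mL, and the shared core is kept intact, the step from the aryl ring to the thiazolyl ring is expected to be small, probably within the scatter or at most a modest move toward more compound being needed. Compound 4 is accordingly estimated at 4.5 ug/mL, with a range from 1.5 ug/mL to 14 ug/mL, which corresponds to an expected step of a 1.6-fold higher number from compound 1 to compound 4 (0.19 log units; within the scatter).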

Compound 4, concentration for half-maximal effect: 3.5 ug/mL
Beside the measured number, compound 4's estimate is 1.3-fold (0.11 log units) above it, and the stated range covers the measured number.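

In this assay, within the data shown here, the exchange at this position gives a 1.2-fold higher number from compound 1 to compound 4 (0.08 log units; within the scatter) and so provides the first step that can be read in this set. Replacing 3-methoxyphenyl with 1,3-thiazol-2-yl on a double-bonded chain carbon bound to a double-bonded chain carbon, and thus a six-membered aromatic ring of carbon only with a five-membered aromatic ring with 2 hetero atoms, leaves the read-out within the scatter. Nothing at hand gives a reason for this result.

This is a single pair, so it does not show whether the same tolerance extends to other groups at this place, such as an amine or a longer chain. It also leaves open whether a carboxylic acid on the 1,3-thiazol-2-yl ring would move the number.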